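Acylurea series: permeability notes on the thiazolyl-to-isopropyl step

The source may report more compounds than this note shows. Statements on the series, on what has been measured and on what is new or still open speak of the compounds shown alone.

Measured so far:
compound 1, `COc1ccccc1C(=O)NC(=O)Nc1ccc(-c2ccccc2)c(C(C)C)c1`: 1.2 10^-6 cm/s
compound 2, `COc1ccccc1C(=O)NC(=O)Nc1ccc(-c2nccs2)c(C(F)(F)F)c1`: 12 10^-6 cm/s

In an ADME assay on LLC-PK1 cells (Sus scrofa) for permeability (a higher number here means that the compound crosses the layer faster, a lower number that the compound crosses the layer more slowly), compound 2 gives 12 10^-6 cm/s and holds the higher of the two numbers; its nearest neighbour, compound 1, gives 1.2 10^-6 cm/s, and that gap lies beyond the scatter. Within the data shown here, compound 1 and compound 2 differ in more than one place, so no single step between them can be read.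

Compound 3, `COc1ccccc1C(=O)NC(=O)Nc1ccc(C(C)C)c(C(F)(F)F)c1`, is not yet measured. It differs from compound 2 in one place: isopropyl in place of 1,3-thiazol-2-yl on an aromatic carbon. The shared core with the acylurea and the trifluoromethyl group is kept.

Among the measured compounds shown here, no measured pair isolates this change, so there is no direct precedent. Because compound 2 gives 12 10^-6 cm/s, compound 3 is estimated close to that, and the step of no change at the digits printed from compound 2 to compound 3 (within the scatter) is expected to stay within the usual scatter, with no clear direction. Compound 3 is estimated at 12 10^-6 cm/s, with a range from 5 10^-6 cm/s to 30 10^-6 cm/s.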

Compound 3, apparent permeability in the LLC-PK1 assay: 2.1 10^-6 cm/s
The estimate for compound 3 lay 5.7-fold (0.76 log units) above the measured number, and the stated range ends above it.
By their numbers in the LLC-PK1 assay, from the lowest: compounds 1 and 3 (each within the scatter of the next); then compound 2.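

Among these compounds, in the LLC-PK1 assay, this position on the shared core is not neutral: isopropyl in place of 1,3-thiazol-2-yl, on the aromatic carbon ortho to a trifluoromethyl group, gives a 5.7-fold lower number from compound 2 to compound 3 (0.76 log units; beyond the scatter), the first single-place step that can be read. In a physicochemical assay for solubility (on this read-out higher numbers stand for higher solubility and lower numbers for lower solubility), compound 2 gives 1.1 ug/mL. In the physicochemical assay compound 3 gives < 1 ug/mL, which is a limit of the assay, so the step on this read-out cannot be read because of that limit: the limit of < 1 ug/mL in the physicochemical assay, at which 1 of the 2 values shown sits.

One step cannot tell whether the lower number in the LLC-PK1 assay follows the loss of the ring or the arrival of the isopropyl group. Going by these compounds, how a cyclopropyl ring or an amine at this place would read in either assay stays open.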